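A few compounds are considered here, and "the series" means these few. Any claim that something is new, unique, unknown or untested is made for them only; others in the source may bear on it.

Of the compounds shown here, three have so far been measured in a functional assay (blood) for inhibition, with Homo sapiens as the target; a lower number here means a stronger inhibitor, a higher number a weaker inhibitor. Compound 1 `CO/N=C(\C)c1ccc(Sc2cc(F)cc(C3CCOCC3)c2)cc1` gives 110 nM in this assay, the highest of the three numbers. Compound 2 `COC1(c2cc(F)cc(Sc3ccc4c(c3)CC/C4=N\OCC#N)c2)CCOCC1` gives 30 nM in this assay, and compound 3 `CO[C@]1(c2cc(F)cc(S(=O)(=O)c3ccc(/C(C)=N/O)cc3)c2)CCO[C@@H](C)C1` gives 20 nM in this assay; both numbers lie below that of compound 1 by more than the usual scatter, but neither compound differs from compound 1 in a single place, so these gaps are not read as steps.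

Compound 4 `C/C(=N\OCCSc1nnnn1C)c1ccc(Sc2cc(F)cc(C3CCOCC3)c2)cc1` has not yet been measured. It differs from compound 1 in one place: ((1-methyl-1H-tetrazol-5-yl)sulfanyl)methyl in place of hydrogen on a saturated chain carbon bound to an oxygen. Read one bond further out, the same change turns the methyl into 2-((1-methyl-1H-tetrazol-5-yl)sulfanyl)ethyl and the methoxy into 2-((1-methyl-1H-tetrazol-5-yl)sulfanyl)ethoxy. Going by the values given here, no pair of measured compounds shows this change, so the size of the step cannot be taken from the data, and the lower numbers of compounds 2 and 3 come with other changes as well.

The step of a 1.8-fold lower number from compound 1 to compound 4 (0.26 log units; within the scatter) is expected to be a modest one toward a lower number, possibly no larger than the scatter. Compound 4 is therefore estimated at 60 nM in this assay, with a range from 20 nM to 200 nM.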

Compound 4, half-maximal inhibitory concentration: 120 nM
Compound 4: the middle estimate sits 2.0-fold (0.30 log units) below what was measured, and the stated range covers the measured number.
By their numbers in this assay, from the lowest: compounds 3 and 2 (each within the scatter of the next); then compounds 1 and 4 (each within the scatter of the next).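

In this assay, going by these compounds alone, putting ((1-methyl-1H-tetrazol-5-yl)sulfanyl)methyl in place of hydrogen on a saturated chain carbon bound to an oxygen gives a 1.1-fold higher number from compound 1 to compound 4 (0.04 log units; within the scatter), the first reading of this position. The position therefore accepts a much larger group, one that carries a five-membered aromatic ring with 4 hetero atoms and turns the methoxy of compound 1 into 2-((1-methyl-1H-tetrazol-5-yl)sulfanyl)ethoxy, with no change in the number that can be told from the scatter. Nothing measured here offers an explanation for this result.

Within the data shown here, the single change leaves open whether other groups at this place, such as an amine, a carboxylic acid or a longer chain without the tetrazole ring, would also leave the number in this assay undisturbed. It also leaves open whether the same change would read alike on the cores of compound 2 and compound 3; neither of these differs from compound 1 in one place.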